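The source may report more compounds than this note shows. Statements on the series, on what has been measured and on what is new or still open speak of the compounds shown alone.

Compounds measured in an assay on CHO cells for displacement of a labelled ligand from adenosine receptor A1 (Homo sapiens), read by scintillation counting, with a stated time of 3 h; a higher number here means a weaker inhibitor, a lower number a stronger inhibitor:
compound 1 `CCn1c(-c2ccccc2)nc2c(NC3CCCCC3)ncnc21`, 10 nM
compound 2 `CCn1c(-c2ccccc2)nc2c(NC3CCC3)ncnc21`, 6 nM
compound 3 `CCn1c(-c2ccccc2)nc2c(NC3CCOC3)ncnc21`, 10 nM

Compound 3 stands level with compound 1 at the digits shown, and compound 2 lies within the scatter of both: the steps of no change at the digits printed from compound 1 to compound 3 (within the scatter) and a 1.7-fold higher number from compound 2 to compound 3 (0.22 log units; within the scatter) are both within the scatter, so the three ring substituents on the nitrogen on the aromatic ring read as equivalent here.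

Compound 4 `CCn1c(-c2ccccc2)nc2c(N)ncnc21` differs from compound 3 by hydrogen in place of oxolan-3-yl on a nitrogen on an aromatic ring. Among the measured compounds shown here, no measured step removes this group altogether; a 1.7-fold lower number from compound 1 to compound 2 (0.22 log units; within the scatter), no change at the digits printed from compound 1 to compound 3 (within the scatter) and a 1.7-fold higher number from compound 2 to compound 3 (0.22 log units; within the scatter) only exchange one ring for another and all sit within the scatter, so they give no direct guide to a bare amino group. A higher number in this assay is nevertheless expected for compound 4, roughly a 30-fold higher number from compound 3 to compound 4 (1.48 log units; beyond the scatter). Compound 4 is estimated at 300 nM, with a range of 30 nM to 3000 nM.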

Compound 4, inhibition constant: 31 nM
Estimate against measurement, compound 4: 9.7-fold (0.99 log units) above; low and high end bracket the measured number.
By their numbers in this assay, from the lowest: compounds 2, 1 and 3 (each within the scatter of the next); then compound 4.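

Removing the ring altogether has an effect that exchanging one ring for another did not show in this assay: hydrogen on this nitrogen gives a 3.1-fold higher number from compound 3 to compound 4 (0.49 log units; beyond the scatter) and likewise a 5.2-fold higher number from compound 2 to compound 4 (0.71 log units; beyond the scatter) and a 3.1-fold higher number from compound 1 to compound 4 (0.49 log units; beyond the scatter), each modest but beyond the scatter. The loss is limited, as compound 4 still reads 31 nM with the bare amino group. Nothing available here explains this difference.

Still open, on these data alone, is whether the ring itself is needed on this nitrogen, or whether a short open chain such as ethyl would match the three rings. Also open, as far as these compounds go, is how a ring carrying an amine or a carboxylic acid would read.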